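A few compounds are considered here, and "the series" means these few. Any claim that something is new, unique, unknown or untested is made for them only; others in the source may bear on it.

Measured compounds:
compound 1, `O=C(N[C@@H](CO)C(=O)NO)c1ccc(C#Cc2ccccc2)cc1`: 28000 nM
compound 2, `CC(NC(=O)c1ccc(C#Cc2ccccc2)cc1)C(=O)NO`: 29000 nM
compound 3, `NC[C@H](NC(=O)c1ccc(C#Cc2ccccc2)cc1)C(=O)NO`: 13000 nM

In a physicochemical assay for solubility (a higher number here means a more soluble compound, a lower number a less soluble compound), compound 3 has the lowest of the three numbers; from compound 1 it was reached by a 2.2-fold lower number from compound 1 to compound 3 (0.33 log units; beyond the scatter) and from compound 2 by a 2.2-fold lower number from compound 2 to compound 3 (0.35 log units; beyond the scatter), while the earlier change a 1.0-fold higher number from compound 1 to compound 2 (0.02 log units; within the scatter) was within the scatter. Compound 4, `CC(C)(NC(=O)c1ccc(C#Cc2ccccc2)cc1)C(=O)NO`, has not yet been measured. Its difference from compound 3 is a group of 7 heavy atoms (4 carbon, 1 nitrogen, 2 oxygen; no ring) in place of a group of 7 heavy atoms (3 carbon, 2 nitrogen, 2 oxygen; no ring), on an amide-type nitrogen, which removes the amino-bearing side chain and brings in a group resembling that of compound 2 with one more methyl. Since both steps into compound 3 lowered the number, the reverse kind of change is expected to raise it, roughly back to the level of compound 2. The expected step is a 1.9-fold higher number from compound 3 to compound 4 (0.28 log units; within the scatter), and compound 4 is estimated at 25000 nM, within 12000 nM to 50000 nM.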

Compound 4, solubility: 182000 nM
Beside the measured number, compound 4's estimate is 7.3-fold (0.86 log units) below it; the whole stated range lies below it.
By their numbers in this assay, from the lowest: compound 3; then compounds 1 and 2 (each within the scatter of the next); then compound 4.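

In this assay, going by these compounds alone, this carbon on the amide-type nitrogen proves far more sensitive than the earlier compounds showed, as a single methyl in place of hydrogen gives a 6.3-fold higher number from compound 2 to compound 4 (0.80 log units; beyond the scatter). The 1-(hydroxycarbamoyl)-1-methylethyl group also stands well clear of the hydroxy-bearing and amino-bearing groups, with a 6.5-fold higher number from compound 1 to compound 4 (0.81 log units; beyond the scatter) and a 14-fold higher number from compound 3 to compound 4 (1.15 log units; beyond the scatter), both larger than any earlier step. No accompanying measurement accounts for this jump. From the compounds shown here alone, whether an ethyl in place of one methyl, or a cyclopropane ring joining the two methyls, would keep so high a number remains open.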